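A Single Group Exchanged on Compound 1

The source may hold more compounds than are shown below. What is called first, only, known or untested is meant among the compounds shown, and "the series" means these compounds.

In a functional assay on the whole organism for inhibition, with Rattus norvegicus as the target (on this read-out lower numbers stand for an effect already at smaller amounts and higher numbers for an effect only at larger amounts of compound), compound 1 (`CCCCc1nc(SC)c(C(=O)C[S+](C)[O-])n1Cc1ccc(-c2ccccc2S(=O)(=O)NC(=O)NCc2ccccc2)cc1`) gives 0.06 mg/kg. Compound 2 (`CCCc1nc(SC)c(C(=O)C[S+]([O-])c2ccccc2)n1Cc1ccc(-c2ccccc2S(=O)(=O)NC(=O)NCc2ccccc2)cc1`) gives 0.04 mg/kg, and compound 3 (`CCCc1nc(SC)c(C(=O)C[S+]([O-])c2ccc(C)cc2)n1Cc1ccc(-c2ccccc2S(=O)(=O)NC(=O)NCc2ccccc2)cc1`) gives 0.03 mg/kg. These three numbers all lie within the usual scatter of one another, so compound 1 stands level with the other two and cannot be ranked against them.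

Compound 4 (`CCCCc1nc(SC)c(C(=O)CS(C)(=O)=O)n1Cc1ccc(-c2ccccc2S(=O)(=O)NC(=O)NCc2ccccc2)cc1`) has not yet been measured. It differs from compound 1 in one place: a group of 4 heavy atoms (1 carbon, 2 oxygen, 1 sulfur; no ring) in place of a group of 3 heavy atoms (1 carbon, 1 oxygen, 1 sulfur; no ring), on a saturated chain carbon bound to a carbonyl carbon. The entering group is methylsulfonyl, and it sits on a saturated chain carbon bound to a carbonyl carbon.

Within the data shown here, no measured pair shows this exchange itself. Among the measured compounds shown here, the only measured step is a 1.3-fold lower number from compound 2 to compound 3 (0.12 log units; within the scatter), which is within the scatter and comes from a different change, methyl in place of hydrogen on an aromatic carbon. Compounds 2 and 3 also differ from compound 1 in more than one place, yet their numbers stay within the scatter of compound 1. This is indirect evidence, but it gives no reason to expect a step beyond the scatter in this assay. The expected change is a 1.2-fold lower number from compound 1 to compound 4 (0.08 log units; within the scatter). For compound 4 the estimated value is 0.05 mg/kg, with an expected range from 0.02 mg/kg to 0.15 mg/kg.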

Compound 4, dose for 50% inhibition: 0.04 mg/kg
Compound 4: middle estimate off by 1.3-fold (0.10 log units), on the high side, within the range that was stated.
By their numbers in this assay, from the lowest: compounds 3, 2, 4 and 1 (each within the scatter of the next).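

Among these compounds, this pair gives the first direct reading of an exchange at this place, on a saturated chain carbon bound to a carbonyl carbon, with the rest of compound 1 left unchanged. Methylsulfonyl, with its added oxygen, gives a 1.5-fold lower number from compound 1 to compound 4 (0.18 log units; within the scatter) in this assay, so the two groups cannot be told apart on this read-out, and the larger group costs no measurable effect in the whole animal. No measurement shown here offers an explanation for the two groups reading alike.

Every compound shown keeps a sulfur atom in the group at this place, so it remains open whether a group without sulfur, such as an amine or a carboxylic acid, would also stand level with compound 1 in this assay. Going by these compounds, it also remains open whether methylsulfonyl is merely one of many groups that fit here or whether a longer chain on the sulfur, such as ethyl or butyl, would begin to shift the dose beyond the usual scatter.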